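The source may hold more compounds than are shown below. What is called first, only, known or untested is meant among the compounds shown, and "the series" means these compounds.

Values so far in a functional assay on MCF7 cells (Homo sapiens) for antiproliferative activity, read by sulforhodamine B assay, with a stated time of 48 h (a lower number here means a stronger inhibitor, a higher number a weaker inhibitor), are as follows.
- compound 1 `COc1ccc(C(=O)/C=C/c2ccccc2-c2ccc(F)cc2)cc1` gives 8800 nM
- compound 2 `COc1ccc(C(=O)/C=C/c2ccccc2-c2ccc(F)nc2)cc1` gives 13000 nM
- compound 3 `O=C(/C=C/c1ccccc1-c1ccc(F)cc1)c1cccc(O)c1` gives 9300 nM

The number for compound 3 lies within the scatter of both other compounds, so the three are not separated. Compound 4 `O=C(/C=C/c1ccccc1-c1ccc(F)nc1)c1cccc(O)c1` has 6-fluoropyridin-3-yl in place of 4-fluorophenyl on an aromatic carbon, ortho to a large group 6-fluoropyridin-3-yl in place of 4-fluorophenyl on an aromatic carbon and is otherwise the same as compound 3. The same exchange has one measured precedent, a 1.5-fold higher number from compound 1 to compound 2 (0.17 log units; within the scatter) and that step stayed within the scatter. The other measured step, a 1.1-fold higher number from compound 1 to compound 3 (0.02 log units; within the scatter) links the two carbonyl-carbon groups and was also within the scatter. The expected step is a 1.3-fold higher number from compound 3 to compound 4 (0.11 log units; within the scatter) and nothing beyond the scatter is expected. The estimate for compound 4 is 12000 nM with an expected range from 6500 nM to 22000 nM in this series.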

Compound 4, half-maximal inhibitory concentration: 12000 nM
The estimate for compound 4 equals the measured number at the digits printed; the range from low to high includes it.
By their numbers in this assay, from the lowest: compounds 1, 3, 4 and 2 (each within the scatter of the next).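

With 3-hydroxyphenyl on the carbonyl carbon, 6-fluoropyridin-3-yl in place of 4-fluorophenyl gives a 1.3-fold higher number from compound 3 to compound 4 (0.11 log units; within the scatter) in this assay, so this exchange now stays within the scatter on two cores: the same change on two cores in this assay, a 1.5-fold higher number (0.17 log units; within the scatter) from compound 1 to compound 2 and a 1.3-fold higher number (0.11 log units; within the scatter) from compound 3 to compound 4, 1.1-fold (0.06 log units) apart, within the scatter of two such steps. The fourth compound also gives a second reading of 3-hydroxyphenyl in place of 4-methoxyphenyl, a 1.1-fold lower number from compound 2 to compound 4 (0.03 log units; within the scatter), and the two readings of that exchange agree: the same change on two cores in this assay, a 1.1-fold higher number (0.02 log units; within the scatter) from compound 1 to compound 3 and a 1.1-fold lower number (0.03 log units; within the scatter) from compound 2 to compound 4, 1.1-fold (0.06 log units) apart, within the scatter of two such steps.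

Still open, as far as these compounds go, is whether any replacement for 4-fluorophenyl moves the number beyond the scatter in this assay. An amine or a carboxylic acid in that place would test this.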